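Methyl in place of hydrogen on the aniline of compound 3

The source may hold more compounds than are shown below. What is called first, only, known or untested is meant among the compounds shown, and "the series" means these compounds.

Going by the values given here, compound 3 `Nc1cccc(-c2cnc3[nH]cc(-c4ccncc4)c3c2)c1` gives 42.7 nM in an assay on isolated protein for inhibition of high affinity nerve growth factor receptor (Homo sapiens), read by 33P incorporation (a lower number here means a stronger inhibitor, a higher number a weaker inhibitor), and stands second highest of the three numbers known; compound 1 `Nc1cc(-c2cnc3[nH]cc(-c4ccncc4)c3c2)ccc1Cl` gives 53.7 nM and compound 2 `Cc1ccc(S(=O)(=O)Nc2cc(N)cc(-c3cnc4[nH]cc(-c5ccncc5)c4c3)c2)cc1` gives 4.62 nM. The step of a 1.3-fold lower number from compound 1 to compound 3 (0.10 log units; within the scatter) lies within the scatter, whereas a 9.2-fold higher number from compound 2 to compound 3 (0.97 log units; beyond the scatter) lies beyond it. Compound 4 `Cc1ccc(-c2cnc3[nH]cc(-c4ccncc4)c3c2)cc1N` differs from compound 3 by methyl in place of hydrogen on an aromatic carbon. Among the compounds with values here, no measured step adds a methyl. Within the data shown here, the only small substituent change seen, a 1.3-fold lower number from compound 1 to compound 3 (0.10 log units; within the scatter), produced nothing beyond the scatter, and the single large gain belongs to compound 2 with its ((4-methylphenyl)sulfonyl)amino group, a much bigger addition. The step expected is therefore a 1.1-fold lower number from compound 3 to compound 4 (0.05 log units; within the scatter). Compound 4 is estimated at 38 nM, with a range of 18 nM to 85 nM.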

Compound 4, half-maximal inhibitory concentration: 22.2 nM
For compound 4 the middle estimate is 1.7-fold (0.23 log units) above the measured one, within the range that was stated.
By their numbers in this assay, from the lowest: compound 2; then compounds 4, 3 and 1 (each within the scatter of the next, the first and the last beyond it).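

Methyl ortho to an amino group and para to a large group gives a 1.9-fold lower number from compound 3 to compound 4 (0.28 log units; within the scatter) in this assay and so stays within the scatter of hydrogen at this position, as chloro does. Going by these compounds alone, the two substituents do separate from each other, with a 2.4-fold lower number from compound 1 to compound 4 (0.38 log units; beyond the scatter) as the first small-group change here to pass the scatter, though only modestly. No measured evidence bears on this difference.
Going by these compounds, whether an ethyl, a methoxy or a dimethylamino group at this position would go beyond the scatter of hydrogen remains open. Also open, on these data alone, is whether methyl here would combine with the ((4-methylphenyl)sulfonyl)amino group of compound 2.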